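This account rests on a few compounds, and the source may have more. Where it says the series, first, only, none or still open, it means among the compounds named here.

Measured in a functional assay on the whole organism with Rattus norvegicus as the target; on this read-out lower numbers stand for an effect already at smaller amounts and higher numbers for an effect only at larger amounts of compound:
- compound 1 `Cn1c(=N)sc2cc(OC(F)(F)F)ccc21`: 5 mg/kg
- compound 2 `N=c1sc2cc(OC(F)(F)F)ccc2n1CCS(=O)(=O)O`: > 10 mg/kg

Compound 2 is known only through a limit, > 10 mg/kg, and not through a number. Compound 3 `C[S+]([O-])Cn1c(=N)sc2cc(OC(F)(F)F)ccc21` has not yet been measured. It differs from compound 2 on a saturated chain carbon bound to an aromatic nitrogen: a group of 3 heavy atoms (1 carbon, 1 oxygen, 1 sulfur; no ring) in place of a group of 5 heavy atoms (1 carbon, 3 oxygen, 1 sulfur; no ring), on a saturated chain carbon bound to an aromatic nitrogen.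

Within the data shown here, one measured step bears on this change. It is an at least 2.0-fold higher number from compound 1 to compound 2 (0.30 log units; that floor lies within the scatter), where sulfomethyl took the place of hydrogen at that same kind of carbon. Its size is open upward, and its floor does not clear the scatter, so it is weak guidance. Among the measured compounds shown here, no measured step shows what the entering group does by itself.

Compound 3 gives up sulfomethyl, so its number in this assay is expected to fall back towards that of compound 1 at 5 mg/kg, with wide uncertainty. The expected change is an at least 1.6-fold lower number from compound 2 to compound 3 (0.22 log units; that floor lies within the scatter), in the direction of a lower number. For compound 3 the estimate is 6 mg/kg, with an expected range from 2 mg/kg to 20 mg/kg.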

Compound 3, dose for half-maximal effect: 2.3 mg/kg
Beside the measured number, compound 3's estimate is 2.6-fold (0.42 log units) above it; measured number inside the range.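

In this assay, the saturated chain carbon bound to an aromatic nitrogen turns out to tolerate more than a hydrogen atom: adding the entering group there gives a 2.2-fold lower number from compound 1 to compound 3 (0.34 log units; beyond the scatter), so substitution at this place need not cost anything in this read-out and can bring a modest gain. Replacing sulfomethyl with that group gives an at least 4.3-fold lower number from compound 2 to compound 3 (0.63 log units; beyond the scatter), which clears the scatter, whereas the floor of the earlier step from the same sulfomethyl compound did not, so the choice of group at this carbon clearly matters. From the compounds shown here alone, the full size of this change remains unknown, and compound 2 is known only through a limit: the limit of > 10 mg/kg in this assay, at which 1 of the 3 values shown sits.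

The compounds shown leave open what an amine, a carboxylic acid or a longer chain would do at this carbon, and so how far the gain extends to other groups. They also do not show whether the sulfur atom of the entering group matters, which an ether chain with oxygen alone in its place could help to settle.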